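The compounds below may be only part of what the source reports. "The series", "measured", "known", "first", "only" and "open" are said of these compounds alone.

Of the compounds shown here, three that share one core have been measured in a functional assay on SGC-7901 cells (Homo sapiens) for inhibition, read by MTT assay, with a stated time of 72 h; on this read-out higher numbers stand for weaker inhibition of growth and lower numbers for stronger inhibition of growth. Compound 1 `O[C@H](COCCOC[C@@H](O)Cc1cn(Cc2ccc3ccccc3c2)nn1)Cc1ccc(-c2ccccc2)cc1` carries a (naphthalen-2-yl)methyl group on an aromatic nitrogen and gives 12100 nM. Compound 2 `CC1=C(CCCCCCCCCCn2cc(C[C@H](O)COCCOC[C@@H](O)Cc3ccc(-c4ccccc4)cc3)nn2)C(=O)c2ccccc2C1=O`, which bears a much larger group on that nitrogen, gives 390 nM. Compound 3 `O[C@H](COCCOC[C@@H](O)Cc1cn(-c2cccnc2)nn1)Cc1ccc(-c2ccccc2)cc1`, with a pyridin-3-yl group on the aromatic nitrogen, gives 29800 nM in this assay; this is the highest of the three numbers, so compound 3 inhibits growth least strongly of the three. For the measured compounds named here, the only single change that touches compound 3 directly is a 2.5-fold higher number from compound 1 to compound 3 (0.39 log units; beyond the scatter).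

Compound 4 `O=c1[nH]c2ccc(-n3cc(C[C@H](O)COCCOC[C@@H](O)Cc4ccc(-c5ccccc5)cc4)nn3)cc2s1` has not yet been measured. It differs from compound 3 in one place: a group of 10 heavy atoms (7 carbon, 1 nitrogen, 1 oxygen, 1 sulfur; one five-membered aromatic ring with 2 hetero atoms, one six-membered aromatic ring of carbon only) in place of a group of 6 heavy atoms (5 carbon, 1 nitrogen; one six-membered aromatic ring with 1 hetero atom), on an aromatic nitrogen. Going by the values given here, the step from compound 1 to compound 3 is the one measured change of the same kind, and it was modest, with the larger group giving the lower number. Among the compounds with values here, compound 2 and compound 3 differ in more than one way, so their values show only that a larger group on this nitrogen can go with a far lower number. Compound 4 is therefore expected to give 12000 nM, within 4000 nM to 35000 nM. This estimate means an expected step of a 2.5-fold lower number from compound 3 to compound 4 (0.40 log units; beyond the scatter).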

Compound 4, concentration for 50% growth inhibition: 10500 nM
Compound 4: the middle estimate sits 1.1-fold (0.06 log units) above what was measured; measured number inside the range.
By their numbers in this assay, from the lowest: compound 2; then compounds 4 and 1 (each within the scatter of the next); then compound 3.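

In this assay, the group that enters in compound 4, with its five-membered and six-membered aromatic rings, gives a 2.8-fold lower number from compound 3 to compound 4 (0.45 log units; beyond the scatter), so a second, quite different larger group also improves on pyridin-3-yl at this aromatic nitrogen. Against the (naphthalen-2-yl)methyl group, the change gives a 1.2-fold lower number from compound 1 to compound 4 (0.06 log units; within the scatter), which lies within the scatter, so a group of carbon only and a group holding nitrogen, oxygen, sulfur and a hydrogen-bond donor cannot be told apart here, even though their atoms differ so much. Nothing measured here explains why either group differs from pyridin-3-yl.

It remains open whether the hydrogen-bond donor of compound 4 matters at all, since no compound shown keeps that group without it. Also open, going by these compounds, is whether a longer carbon chain between this nitrogen and the naphthalen-2-yl or pyridin-3-yl ring, or an amine or a carboxylic acid on that ring, would bring the number closer to the much lower value of compound 2, 390 nM.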